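The source may hold more compounds than are shown below. What is called first, only, known or untested is meant among the compounds shown, and "the series" means these compounds.

Three compounds built on a shared core differ only in the group carried on one aromatic carbon. Compound 1 `CNc1nc(N)nc2c1ncn2/C=C1/CC1(CO)CO` bears a methylamino group, and in an ADME assay on BCBL1 cells (Homo sapiens) for cytotoxicity, with a stated time of 7 days (a lower number here means that less compound is tolerated, a higher number that more compound is tolerated), compound 1 gives 67000 nM. Compound 2 `Nc1nc(OCc2ccccc2)c2ncn(/C=C3/CC3(CO)CO)c2n1` carries a benzyloxy group in its place, and in this assay compound 2 gives only a limit of the assay, > 20000 nM, not a number. Compound 3 `CSc1nc(N)nc2c1ncn2/C=C1/CC1(CO)CO` carries a methylsulfanyl group, and in this assay compound 3 likewise gives a limit, > 20000 nM. Compound 3 thus stands at the limit of > 20000 nM in this assay, at which 2 of the 3 values shown sit, which holds two of the three values. Among the measured compounds shown here, the steps a step that the limit leaves unreadable from compound 1 to compound 2 and a step that the limit leaves unreadable from compound 1 to compound 3 are left unreadable by that limit, and the step that the two limits leave unreadable from compound 2 to compound 3 is hidden by two limits, so no measured step has a readable size.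

Compound 4 `CCCCSc1nc(N)nc2c1ncn2/C=C1/CC1(CO)CO` differs from compound 3 by propyl in place of hydrogen on a saturated chain carbon bound to a sulfur, the methylsulfanyl becoming butylsulfanyl. For the measured compounds named here, none of the measured steps touches a sulfanyl chain, and the only numerical anchor is compound 1 with 67000 nM. The expected step that the limit leaves unreadable from compound 3 to compound 4 is therefore judged to stay within the scatter. Compound 4 is estimated to give 30000 nM, between 8000 nM and 100000 nM.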

Compound 4, half-maximal cytotoxic concentration: > 20000 nM
Compound 4 ended at the assay's limit (the forecaster's own chance of this, stated with the estimate: 55%); the middle value does not contradict the limit.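

Compound 4 also gives only a limit of the assay, so none of its steps to compound 1, compound 2 or compound 3 can be read in this assay: the limit of > 20000 nM in this assay, at which 3 of the 4 values shown sit.

The compounds shown leave open whether compound 2, compound 3 and compound 4 differ from one another, or from compound 1, in this assay at all.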